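The compounds below may be only part of what the source reports. "The series", "measured", "known", "first", "only" and "open" are said of these compounds alone.

Compound 1 `CC(/C=N/Nc1ccc([N+](=O)[O-])cc1)=N\NC(=O)c1ccccc1Cl`, compound 2 `CC(/C=N/Nc1ccc([N+](=O)[O-])cc1)=N\NC(=O)c1ccccc1` and compound 3 `CC(/C=N/Nc1ccc([N+](=O)[O-])cc1)=N\NC(=O)c1ccccc1Nc1ccccc1` share one core and differ only in a single group on one of its aromatic rings. All three were examined in a functional assay on cells (Splenocyte, Mus musculus, strain BALB/c) for inhibition, read by scintillation counting and thymidine incorporation, with a stated time of 72 h; on this read-out lower numbers stand for stronger inhibition and higher numbers for weaker inhibition. For compound 1 the result in this assay is the limit > 12000 nM, a boundary of the measurement rather than a number. For compound 2 the result is likewise the limit > 12000 nM. The step that the two limits leave unreadable from compound 1 to compound 2, hydrogen in place of chloro on an aromatic carbon, therefore has no readable size. For compound 3 no result was reported in this assay: "not determined" (no result reported). Compound 3 thus stands nowhere on the numbers; what surrounds it is the limit of > 12000 nM in this assay, at which 2 of the 3 values shown sit, so its two closest relatives both sit at the boundary of the measurement.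

Compound 4 `CC(/C=N/Nc1ccc([N+](=O)[O-])cc1)=N\NC(=O)c1ccccc1O` has not yet been measured. It differs from compound 3 by hydroxy in place of anilino on an aromatic carbon. Among the compounds with values here, no measured step bears directly on this change, and the only step that exists lies between two limits and cannot be sized. With both measured relatives at the boundary, weak inhibition is expected for compound 4 as well, and most likely only a limit will be reported. Compound 4 is therefore estimated at about 15000 nM, within a range from 3000 nM to 60000 nM.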

Compound 4, half-maximal inhibitory concentration: 1640 nM
Estimate against measurement, compound 4: 9.1-fold (0.96 log units) above; measured number outside the range, below it.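

At this position on the aromatic ring, hydroxy is the only group shown that brings a compound within the measurable range of this assay, so this one position can decide whether a readable inhibition appears at all. Hydroxy in place of hydrogen gives an at least 7.3-fold lower number from compound 2 to compound 4 (0.86 log units; beyond the scatter), and hydroxy in place of chloro gives an at least 7.3-fold lower number from compound 1 to compound 4 (0.86 log units; beyond the scatter), so a change of one small group on the shared core is enough to move the result off the boundary of the measurement. Both sizes are only minimum values, and the step between the other two measured compounds cannot be read, since neither of those compounds has a number to compare: the limit of > 12000 nM in this assay, at which 2 of the 4 values shown sit.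

The compounds shown leave open whether the gain belongs to hydroxy itself or would also come with another small group here, such as an amine. A methoxy group, which keeps the oxygen but carries no hydrogen on it, or a carboxylic acid would help show which feature of hydroxy the inhibition follows.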